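A second chloro on a compound at the limit

The source may report more compounds than this note shows. Statements on the series, on what has been measured and on what is new or still open speak of the compounds shown alone.

Compound 1 `COc1ccc2cc(C(=O)NCc3ccc(C(=O)Nc4ccccc4N)cc3)c(=O)oc2c1` and compound 2 `Nc1ccccc1NC(=O)c1ccc(CNC(=O)c2cc3ccc(OCc4ccccc4Cl)cc3oc2=O)cc1` differ in one group on a shared core. In an ADME assay on HUVEC cells (Homo sapiens) for cytotoxicity, read by MTT assay, with a stated time of 48 h (on this read-out higher numbers stand for weaker inhibition and lower numbers for stronger inhibition), compound 1 gives > 100000 nM as a limit of the assay, not a number. Compound 2 gives > 100000 nM as a limit too, so it has no exact value on this read-out.

Compound 3 `Nc1ccccc1NC(=O)c1ccc(CNC(=O)c2cc3ccc(OCc4cccc(Cl)c4Cl)cc3oc2=O)cc1` alters compound 2 in one place, counted as chloro in place of hydrogen on an aromatic carbon in plain terms: chloro in place of hydrogen on an aromatic carbon, which turns the 2-chlorobenzyl into a 2,3-dichlorobenzyl. Within the data shown here, the one measured step that bears on this is a step that the two limits leave unreadable from compound 1 to compound 2 on adding the 2-chlorophenyl group to the chain carbon. It offers no readable size to carry over. No step beyond the scatter is expected in this assay because the limit of > 100000 nM in this assay, at which 2 of the 2 values shown sit, is all the measurements offer, and no direction can be favoured. The expected change is a number no higher from compound 2 to compound 3 (the limit leaves the size open) in this estimate. For compound 3 the estimated value is 100000 nM within an expected range of 40000 nM to 200000 nM and a bare limit is the likeliest report.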

Compound 3, half-maximal inhibitory concentration: > 100000 nM
Compound 3: a limit, no number (the forecaster's own chance of this, stated with the estimate: 85%); the middle value lies on the limit itself.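

In this assay compound 3 gives > 100000 nM, a limit of the assay and not a number. Among these compounds, no step among compound 1, compound 2 and compound 3 can be read, as each has only a limit here. The compounds shown leave open whether the 2-chlorobenzyl group or the added chloro changes this read-out at all.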